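The source may report more compounds than this note shows. Statements on the series, on what has been measured and on what is new or still open speak of the compounds shown alone.

Measured so far in a functional assay on A549 cells (Homo sapiens) for cytotoxicity, read by MTT assay, with a stated time of 72 h; a lower number here means a stronger inhibitor, a higher number a weaker inhibitor
- compound 1 `CSc1nc(Br)c(C(=O)c2ccccc2)s1` gives 97000 nM
- compound 2 `O=C(c1ccccc1)c1sc(N2CCCC2)nc1Br` gives 97000 nM
- compound 3 `O=C(c1ccccc1)c1sc(N2CCCCC2)nc1Cl` gives 41000 nM

Compound 3 carries the lowest number of the three in this assay, with compound 1 and compound 2 both sitting higher by the same margin, beyond the scatter. The next step leads to compound 4 `O=C(c1ccccc1)c1sc(N2CCCCC2)nc1Br`, which has bromo in place of chloro on an aromatic carbon. The piperidin-1-yl group stays as it is.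

Among the measured compounds shown here, no measured step exchanges chloro for bromo. For the measured compounds named here, the one step available, no change at the digits printed from compound 1 to compound 2 (within the scatter), puts pyrrolidin-1-yl in place of methylsulfanyl with bromo kept, and it shows no change. It bears only indirectly on this swap. Bromo-bearing compound 2 stands at 97000 nM, but it also differs from compound 3 in its pyrrolidin-1-yl group, so the halogen's share cannot be separated. A slight drift to a higher number is therefore expected, and no step beyond the scatter. The expected step is a 1.5-fold higher number from compound 3 to compound 4 (0.17 log units; within the scatter). For compound 4 the estimated value is 60000 nM, with an expected range of 28000 nM to 120000 nM.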

Compound 4, half-maximal inhibitory concentration: 48000 nM
Compound 4: the middle estimate sits 1.3-fold (0.10 log units) above what was measured; the range from low to high includes it.
By their numbers in this assay, from the lowest: compounds 3 and 4 (each within the scatter of the next); then compounds 1 and 2 (each within the scatter of the next).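

In this assay the swap at the aromatic carbon next to the ring nitrogen now has a direct reading with piperidin-1-yl held constant: a 1.2-fold higher number from compound 3 to compound 4 (0.07 log units; within the scatter) shows that chloro and bromo cannot be told apart here. Among the compounds shown here, with bromo kept, the ring atom that bears the amine gives the first step beyond the scatter, since a 2.0-fold lower number from compound 2 to compound 4 (0.31 log units; beyond the scatter) and a 2.0-fold lower number from compound 1 to compound 4 (0.31 log units; beyond the scatter) both favour piperidin-1-yl, though only modestly. Nothing available gives a cause for either the flat halogen swap or the modest piperidin-1-yl steps.

The compounds shown leave open whether any halogen matters at this carbon, as a hydrogen, methyl or nitrile there remains unread. Also open, from the compounds shown here alone, is how a morpholin-4-yl group or a longer alkylamino chain would compare with piperidin-1-yl.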